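Branching the ketone side chain

A few compounds are considered here, and "the series" means these few. Any claim that something is new, unique, unknown or untested is made for them only; others in the source may bear on it.

Compound 1 `COc1cc(C(=O)O)ccc1OCCCCOc1ccc(C(=O)CC(C)C)c(O)c1C`, compound 2 `CCCC(=O)c1ccc(OCCCCOc2cc(C(=O)O)ccc2OC)c(C)c1O` and compound 3 `COc1ccc(C(=O)O)cc1OCCCCOc1ccc(C(=O)CC(C)C)c(O)c1C` were measured in an ADME assay on a cell-free system (plasma, Rattus norvegicus) for metabolic stability, read by LC-MS, with a stated time of 60 min, tested at 100 uM; a lower number here means that less of the compound is left, a higher number that more of the compound is left. Compound 1 gives 99%, compound 2 gives 78% and compound 3 gives 99%. Compound 2 and compound 3 differ only by methyl in place of hydrogen on a saturated chain carbon bound to two saturated chain carbons, and that step reads a number 21 percentage points higher from compound 2 to compound 3 (beyond the scatter). Compound 1 and compound 3 stand level within the scatter; the difference between the two cores of compound 1 and compound 2 is not broken down here. Compound 4 `COc1cc(C(=O)O)ccc1OCCCCOc1ccc(C(=O)CC(C)(C)C)c(O)c1C` is not yet measured. It differs from compound 1 by methyl in place of hydrogen on a saturated chain carbon bound to three saturated chain carbons, the same kind of change as before, though here the place is a saturated chain carbon bound to three saturated chain carbons rather than two. Because compound 1 already gives 99%, little room is left, and the step is expected to be a number 1 percentage points lower from compound 1 to compound 4 (within the scatter). Compound 4 is therefore estimated at 98%, between 92% and 100%.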

Compound 4, percent of the compound remaining: 48%
Compound 4: middle estimate off by 50 percentage points, on the high side; the measured number lies below the stated range.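

In this assay the isobutyl to neopentyl change on the core of compound 1 reads a number 51 percentage points lower from compound 1 to compound 4 (beyond the scatter). The added methyl therefore did not carry its direction from one core to the other: the same change on two cores in this assay, a number 21 percentage points higher (beyond the scatter) from compound 2 to compound 3 and a number 51 percentage points lower (beyond the scatter) from compound 1 to compound 4, 72 percentage points apart, beyond the scatter of two such steps This rests on one pair per core, and the place also differs, a saturated chain carbon bound to two saturated chain carbons in one pair and to three in the other, so it does not show whether core or place accounts for the gap.

The compounds shown leave open how neopentyl reads on the core of compound 3, which would help separate the two. Also open, from the compounds shown here alone, is how a longer chain on the ketone would read in this assay.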